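Working notes on compound 3 in the NCI-H23 series

The source may report more compounds than this note shows. Statements on the series, on what has been measured and on what is new or still open speak of the compounds shown alone.

Measured so far:
compound 1 `COc1cc(/C=C/C(=O)c2cccc(-n3cc(-c4ccccc4)[nH]c3=O)c2)cc(OC)c1OC`: 1430 nM
compound 2 `COc1ccc(-c2cn(-c3cccc(C(=O)/C=C/c4cc(OC)c(OC)c(OC)c4)c3)c(=O)[nH]2)cc1`: 1630 nM

Among the measured compounds shown here, in a functional assay on NCI-H23 cells (Homo sapiens) for inhibition (on this read-out lower numbers stand for stronger inhibition of growth and higher numbers for weaker inhibition of growth), compound 2 gives 1630 nM and stands within the scatter of compound 1, the only other measured compound; the step of a 1.1-fold higher number from compound 1 to compound 2 (0.06 log units; within the scatter) is the sole measured change. Compound 3 `COc1cc(/C=C/C(=O)c2cccc(-n3cc(-c4cc(OC)c(OC)c(OC)c4)[nH]c3=O)c2)cc(OC)c1OC` differs from compound 2 by 3,4,5-trimethoxyphenyl in place of 4-methoxyphenyl on an aromatic carbon. The step of a 1.1-fold higher number from compound 1 to compound 2 (0.06 log units; within the scatter) added a methoxy to the same phenyl without a change beyond the scatter, so for compound 3 no step beyond the scatter is expected, a 1.0-fold higher number from compound 2 to compound 3 (0.02 log units; within the scatter). Compound 3 is therefore estimated at 1700 nM, with an expected range of 600 nM to 4800 nM.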

Compound 3, concentration for 50% growth inhibition: 2000 nM
Estimate against measurement, compound 3: 1.2-fold (0.07 log units) below, within the range that was stated.
By their numbers in this assay, from the lowest: compounds 1, 2 and 3 (each within the scatter of the next).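

In this assay, the step to the largest group shown at this position stays within the scatter: a 1.2-fold higher number from compound 2 to compound 3 (0.09 log units; within the scatter). The same holds against the unsubstituted phenyl: a 1.4-fold higher number from compound 1 to compound 3 (0.15 log units; within the scatter). Thus, phenyl, 4-methoxyphenyl and 3,4,5-trimethoxyphenyl on this aromatic carbon cannot be told apart on this read-out, and nothing available explains this.

The compounds shown vary this position only through methoxy groups on a phenyl ring. On these data alone, whether an amine or a carboxylic acid on that phenyl, or a longer alkyl chain in its place, would move the number beyond the scatter remains open.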